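The source may hold more compounds than are shown below. What is called first, only, known or untested is meant among the compounds shown, and "the series" means these compounds.

Compound 1 `Cn1cc(/C=C2/C(=O)Nc3ccccc32)c2cc(Nc3nccc(-c4ccc(O)cc4)n3)ccc21`: 13200 nM
Compound 2 `Cn1cc(/C=C2/C(=O)Nc3ccccc32)c2cc(Nc3nccc(-c4ccc(Cl)cc4)n3)ccc21`: 5820 nM

In a functional assay on U-87MG ATCC cells (Homo sapiens) for cytotoxicity, read by MTT assay, with a stated time of 48 h (on this read-out lower numbers stand for stronger inhibition and higher numbers for weaker inhibition), compound 2 gives 5820 nM, the lowest of the two numbers shown. Among the compounds with values here, compound 1 gives 13200 nM, and the only measured step is a 2.3-fold lower number from compound 1 to compound 2 (0.36 log units; beyond the scatter), a swap of a small group on the same ring that compound 3 now changes. Compound 3 `Cn1cc(/C=C2/C(=O)Nc3ccccc32)c2cc(Nc3nccc(-c4cccs4)n3)ccc21` carries thiophen-2-yl in place of 4-chlorophenyl on an aromatic carbon. Within the data shown here, no measured step swaps one whole ring for another, so the step into compound 3 is expected to stay small, a 1.4-fold higher number from compound 2 to compound 3 (0.14 log units; within the scatter), a change within the scatter. Compound 3 is therefore estimated at 8000 nM, with a range of 3000 nM to 20000 nM.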

Compound 3, half-maximal inhibitory concentration: 7180 nM
The estimate for compound 3 lay 1.1-fold (0.05 log units) above the measured number; the range from low to high includes it.
By their numbers in this assay, from the lowest: compounds 2, 3 and 1 (each within the scatter of the next, the first and the last beyond it).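

In this assay, a whole ring can be exchanged at this aromatic carbon, not just a small group on it: replacing 4-chlorophenyl with the smaller, five-membered thiophen-2-yl gives a 1.2-fold higher number from compound 2 to compound 3 (0.09 log units; within the scatter). Replacing 4-hydroxyphenyl with thiophen-2-yl gives a 1.8-fold lower number from compound 1 to compound 3 (0.26 log units; within the scatter), so this ring cannot be told apart from either six-membered ring in this assay. No supporting measurement is available to explain this result. Going by these compounds, what remains open is how the number would respond to a pyridine ring at this carbon, or to an amine or a carboxylic acid on the thiophene.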